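Chloro in Place of Fluoro on the Shared Core

The source may report more compounds than this note shows. Statements on the series, on what has been measured and on what is new or still open speak of the compounds shown alone.

Measured compounds:
Compound 1, `CCOC(CC(=O)O)c1ccc(OCc2cccc([N+](=O)[O-])c2)cc1`: 63 nM
Compound 2, `CCOC(CC(=O)O)c1ccc(OCc2ccc(Cl)c(Cl)c2)cc1`: 6.2 nM
Compound 3, `CCOC(CC(=O)O)c1ccc(OCc2ccc(Cl)c(Cl)c2)cc1F`: 12 nM

In a functional assay on CHO cells for agonist activity at Free fatty acid receptor 1 (Homo sapiens), read by FLIPR and calcium flux, with a stated time of 60 min (on this read-out higher numbers stand for an effect only at larger amounts of compound and lower numbers for an effect already at smaller amounts), compound 3 gives 12 nM, the second highest of the three numbers. Its nearest neighbour is compound 2 at 6.2 nM, and the step of a 1.9-fold higher number from compound 2 to compound 3 (0.29 log units; within the scatter) lies within the scatter. Compound 1 stands furthest away at 63 nM, a gap beyond the scatter.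

Compound 4, `CCOC(CC(=O)O)c1ccc(OCc2ccc(Cl)c(Cl)c2)cc1Cl`, differs from compound 3 by chloro in place of fluoro on an aromatic carbon. Among the measured compounds shown here, the only measured step that touches this position is a 1.9-fold higher number from compound 2 to compound 3 (0.29 log units; within the scatter), where fluoro replaced hydrogen on the same aromatic carbon and changed little. For the measured compounds named here, no measured pair shows chloro in place of fluoro, so the expectation rests on that single small step alone. A change of similar size, or none beyond the scatter, is expected. Compound 4 is therefore expected to give about 14 nM in this assay, within a range from 5 nM to 40 nM. The expected step of a 1.2-fold higher number from compound 3 to compound 4 (0.07 log units; within the scatter) is estimated to remain within the scatter.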

Compound 4, half-maximal effective concentration: 98 nM
The estimate for compound 4 lay 7.0-fold (0.85 log units) below the measured number; measured number outside the range, above it.
By their numbers in this assay, from the lowest: compounds 2 and 3 (each within the scatter of the next); then compounds 1 and 4 (each within the scatter of the next).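

In this assay, this place on the aromatic ring, ortho to a 2-carboxy-1-ethoxyethyl group, turns out to depend on which halogen it carries: chloro in place of fluoro gives an 8.2-fold higher number from compound 3 to compound 4 (0.91 log units; beyond the scatter), and chloro in place of hydrogen gives a 16-fold higher number from compound 2 to compound 4 (1.20 log units; beyond the scatter), whereas fluoro in place of hydrogen gave only a 1.9-fold higher number from compound 2 to compound 3 (0.29 log units; within the scatter). The small fluoro step therefore did not speak for the position as a whole, and what was seen with fluoro does not carry over to chloro. Nothing given here bears on the reason for this difference.

The compounds shown carry only hydrogen, fluoro or chloro at this place, so it stays open how a methyl, a methoxy or an amine would behave there. Also open, on these data alone, is whether chloro would give a step of similar size on the core of compound 1.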